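This account rests on a few compounds, and the source may have more. Where it says the series, first, only, none or still open, it means among the compounds named here.

For the measured compounds named here, in a functional assay on SiHa cells (Homo sapiens) for antiproliferative activity, read by CCK-8 assay, with a stated time of 72 h (a lower number here means a stronger inhibitor, a higher number a weaker inhibitor), three compounds with a shared core have numbers so far. Compound 1 `COc1ccc(-c2cncnc2-c2cc(OC)c(OC)c(OC)c2)cc1O` gives 2750 nM, compound 2 `COc1ccc(-c2cncnc2-c2cc(OC)c(OC)c(OC)c2)cc1F` gives 3340 nM, and compound 3 `COc1ccc(-c2cncnc2-c2cc(OC)c(OC)c(OC)c2)cc1Cl` gives 1330 nM, the lowest of the three. Fluoro in place of hydroxy gives a 1.2-fold higher number from compound 1 to compound 2 (0.08 log units; within the scatter). Chloro in place of hydroxy gives a 2.1-fold lower number from compound 1 to compound 3 (0.32 log units; beyond the scatter), and chloro in place of fluoro gives a 2.5-fold lower number from compound 2 to compound 3 (0.40 log units; beyond the scatter). Compound 4 `CCSc1ccc(-c2cncnc2-c2cc(OC)c(OC)c(OC)c2)cc1` differs from compound 3 by a larger exchange: 4-(ethylsulfanyl)phenyl in place of 3-chloro-4-methoxyphenyl on an aromatic carbon. Going by the values given here, no measured step tests this exchange directly, and nothing yet shows how the ethylsulfanyl group behaves. Still, compound 4 no longer has the chloro group, and adding chloro gave a 2.5-fold lower number from compound 2 to compound 3 (0.40 log units; beyond the scatter), so a modest rise in the number seems more likely than a further fall. The expected change is a 1.5-fold higher number from compound 3 to compound 4 (0.18 log units; within the scatter), with real uncertainty in both directions. For compound 4 the estimated value is 2000 nM, within an expected range of 500 nM to 6000 nM.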

Compound 4, half-maximal inhibitory concentration: 1030 nM
The estimate for compound 4 lay 1.9-fold (0.29 log units) above the measured number; measured number inside the range.
By their numbers in this assay, from the lowest: compounds 4 and 3 (each within the scatter of the next); then compounds 1 and 2 (each within the scatter of the next).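

In this assay, the position on the shared core accepts an exchange of the whole aryl group, not just of one small group on it: 4-(ethylsulfanyl)phenyl in place of 3-chloro-4-methoxyphenyl gives a 1.3-fold lower number from compound 3 to compound 4 (0.11 log units; within the scatter) and so leaves the number within the scatter. The same exchange gives a 3.2-fold lower number from compound 2 to compound 4 (0.51 log units; beyond the scatter) and, starting from the 3-hydroxy-4-methoxyphenyl group, a 2.7-fold lower number from compound 1 to compound 4 (0.43 log units; beyond the scatter), so neither chloro nor methoxy is needed on this ring for a number in the range of compound 3. No measurement shown here accounts for these results.

Methoxy and the group beside the ring's other substituent both leave in this one exchange, so the part played by each stays unresolved. Also open, as far as these compounds go, is how 4-(methylsulfanyl)phenyl, 4-(propylsulfanyl)phenyl or an amine in place of the sulfur would compare.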